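This account rests on a few compounds, and the source may have more. Where it says the series, first, only, none or still open, it means among the compounds named here.

Compound 1 `CC(C(=O)NCc1ccc(C(F)(F)F)nc1NC1CCCCC1)c1ccc(NS(C)(=O)=O)c(F)c1` gives 260 nM in a functional assay on CHO-K1 cells for antagonist activity at transient receptor potential cation channel subfamily V member 1 (Homo sapiens), read by FLIPR; on this read-out lower numbers stand for stronger inhibition and higher numbers for weaker inhibition.
Compound 2 `CC(C(=O)NCc1ccc(C(F)(F)F)nc1N(C)C)c1ccc(NS(C)(=O)=O)c(F)c1` gives 2390 nM in this assay.

Of these two numbers, compound 2 has the highest. Compound 3 `CC(C(=O)NCc1ccc(C(F)(F)F)nc1N1CCC(C)(C)CC1)c1ccc(NS(C)(=O)=O)c(F)c1` differs from compound 2 by 4,4-dimethylpiperidin-1-yl in place of dimethylamino on an aromatic carbon. Going by the values given here, the only measured step that bears on this change is a 9.2-fold higher number from compound 1 to compound 2 (0.96 log units; beyond the scatter), in which a ring-bearing amino group gave way to dimethylamino. Compound 3 brings back a ring at the same place, so a step to a lower number in this assay is expected, a 6.0-fold lower number from compound 2 to compound 3 (0.78 log units; beyond the scatter). Compound 3 is therefore estimated at 400 nM, with a range from 120 nM to 1500 nM.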

Compound 3, half-maximal inhibitory concentration: 8 nM
The estimate for compound 3 lay 50-fold (1.70 log units) above the measured number; measured number below the stated range.
By their numbers in this assay, from the lowest: compound 3; then compound 1; then compound 2.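

In this assay, the group next to the ring nitrogen matters far more than the earlier pair showed: 4,4-dimethylpiperidin-1-yl brings a 300-fold lower number from compound 2 to compound 3 (2.48 log units; beyond the scatter) in place of dimethylamino. A ring alone does not account for the gain, as cyclohexylamino also carries one and the change to 4,4-dimethylpiperidin-1-yl still brings a 33-fold lower number from compound 1 to compound 3 (1.51 log units; beyond the scatter) in this read-out. Nothing measured here explains the size of these steps.

Open is whether the two methyl groups count, since plain piperidin-1-yl is not among the compounds shown. Also open, as far as these compounds go, is how a morpholine ring, with an oxygen in it, would compare.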